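Removing the para chloro from compound 2: a benzofuran series

The source may report more compounds than this note shows. Statements on the series, on what has been measured and on what is new or still open speak of the compounds shown alone.

Compound 2 `CCCCc1oc2ccc(/N=C/c3ccc(Cl)cc3)cc2c1C(=O)c1ccc(OC)cc1` is one of two analogs tested in a functional assay, with a stated time of 30 min (a higher number here means a weaker inhibitor, a lower number a stronger inhibitor), and in that assay compound 2 gives 75.9 ug/mL, the highest of the two numbers. Among the compounds with values here, its nearest neighbour, compound 1 `CCCCc1oc2ccc(/N=C/c3ccc(C#N)cc3)cc2c1C(=O)c1ccc(OC)cc1`, gives 27.2 ug/mL in this assay, so the only measured step, a 2.8-fold higher number from compound 1 to compound 2 (0.45 log units; beyond the scatter), is a modest one beyond the scatter. Compound 3 `CCCCc1oc2ccc(/N=C/c3ccccc3)cc2c1C(=O)c1ccc(OC)cc1` is the next member; it differs from compound 2 as follows: hydrogen in place of chloro on an aromatic carbon. Within the data shown here, no measured pair shows this exact change, and the one step available concerns the swap of one group on that same aromatic carbon for another, not its loss. Among the measured compounds shown here, that step argues only that the group at this position matters modestly. The author therefore expects a small step for a 1.1-fold lower number from compound 2 to compound 3 (0.04 log units; within the scatter) in either direction, possibly within the scatter, and estimates that compound 3 will give about 70 ug/mL in this assay, within a range from 30 ug/mL to 160 ug/mL.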

Compound 3, half-maximal inhibitory concentration: 34.2 ug/mL
Estimate against measurement, compound 3: 2.0-fold (0.31 log units) above, within the range that was stated.
By their numbers in this assay, from the lowest: compounds 1 and 3 (each within the scatter of the next); then compound 2.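

Going from 4-chlorophenyl to phenyl gives a 2.2-fold lower number from compound 2 to compound 3 (0.35 log units; beyond the scatter) in this assay, so removing the chloro outright, and not only swapping it for cyano, shifts the number at this position. Hydrogen and cyano on this aromatic carbon cannot be told apart, with a 1.3-fold higher number from compound 1 to compound 3 (0.10 log units; within the scatter), which leaves compound 2 as the only one of the three set apart from the others by a step beyond the scatter. Nothing available bears on the cause of this result.

The compounds shown leave open how other groups on this aromatic carbon, such as an amine or a carboxylic acid, would read in this assay. They also leave open whether chloro would stand apart in the same way from hydrogen and cyano if the shared core were changed elsewhere.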